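Swapping the Side Group on a Shared Core

The compounds below may be only part of what the source reports. "The series", "measured", "known", "first", "only" and "open" are said of these compounds alone.

For the measured compounds named here, compound 3 `CN1CCCCC1CNc1nc2c(c(Nc3ccc(C(F)(F)F)cc3)n1)CCN(c1ncccc1C(F)(F)F)CC2` stands highest of the three compounds measured so far in a physicochemical assay for solubility, in simulated intestinal fluid, measured as thermodynamic solubility, at pH 6.8 (on this read-out higher numbers stand for higher solubility and lower numbers for lower solubility), where compound 3 gives 254 ug/mL. Compound 2 `CCC(CC)N1CCN(c2nc3c(c(Nc4ccc(C(F)(F)F)cc4)n2)CCN(c2ncccc2C(F)(F)F)CC3)CC1` gives 109 ug/mL, and compound 1 `CC(=O)NC1CCN(c2nc3c(c(Nc4ccc(C(F)(F)F)cc4)n2)CCN(c2ncccc2C(F)(F)F)CC3)C1` gives 19 ug/mL. The distances are a 2.3-fold higher number from compound 2 to compound 3 (0.37 log units; beyond the scatter) and a 13-fold higher number from compound 1 to compound 3 (1.13 log units; beyond the scatter), while the remaining step is a 5.7-fold higher number from compound 1 to compound 2 (0.76 log units; beyond the scatter).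

Compound 4 `NC1CCN(c2nc3c(c(Nc4ccc(C(F)(F)F)cc4)n2)CCN(c2ncccc2C(F)(F)F)CC3)C1` has not yet been measured. It differs from compound 3 in one place: 3-aminopyrrolidin-1-yl in place of ((1-methylpiperidin-2-yl)methyl)amino on an aromatic carbon. Going by the values given here, the step that bears most closely on this change is the one from compound 1, which also carries a pyrrolidine ring at this position, though with acetamido where compound 4 carries amino; that step was a 13-fold higher number from compound 1 to compound 3 (1.13 log units; beyond the scatter). Returning to a pyrrolidine ring may therefore give back part of that step, but the data do not separate the acetamido of compound 1 from the amino of compound 4, so the size is uncertain. A modest decrease is expected, written as a 1.7-fold lower number from compound 3 to compound 4 (0.23 log units; within the scatter). Compound 4 is estimated to give 150 ug/mL in this assay, with a range from 40 ug/mL to 500 ug/mL.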

Compound 4, solubility: > 215 ug/mL
Compound 4: a limit, no number; the forecaster's own chance of this, stated with the estimate: 10%; middle value at least 1.4-fold (0.15 log units) away from the limit.
By their numbers in this assay, from the lowest: compound 1; then compound 2; then compound 3.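

In this assay the result for compound 4 is a limit of the assay and not a number: the limit of > 215 ug/mL in this assay, at which 1 of the 4 values shown sits.

Keeping the pyrrolidine ring on the shared core and placing hydrogen where compound 1 carries acetyl on the amine nitrogen gives an at least 11-fold higher number from compound 1 to compound 4 (1.05 log units; beyond the scatter), so this ring at this position does not by itself hold the number at the low level of compound 1, a point the earlier compounds could not settle. Set against the piperazine of compound 2, the 3-aminopyrrolidin-1-yl group gives an at least 1.9-fold higher number from compound 2 to compound 4 (0.29 log units; that floor lies within the scatter), while the step between compound 3 and compound 4 cannot be read, so these two side groups cannot be put in order.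

As far as these compounds go, how far the number of compound 4 actually lies past its limit remains open, and with it whether the smaller group matches or passes the ((1-methylpiperidin-2-yl)methyl)amino group of compound 3. Also open, from the compounds shown here alone, is how other groups on that pyrrolidine nitrogen would read, such as a single methyl or a carboxylic acid on a short chain.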